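From Chloro to Methoxy on a Weak Inhibitor

The source may hold more compounds than are shown below. What is called first, only, known or untested is meant among the compounds shown, and "the series" means these compounds.

Compound 1 `Cc1cc(-c2ccc(Cl)cc2)cc(=O)o1` was examined in a functional assay on K562 cells (Homo sapiens) for inhibition; a lower number here means a stronger inhibitor, a higher number a weaker inhibitor. In this assay compound 1 gives only a limit of the assay, > 50000 nM. Compound 2 `Cc1cc(/C=C/c2ccccc2)cc(=O)o1` likewise reaches only a limit in this assay, > 50000 nM. Compound 3 `CCCC#Cc1cc(C)oc(=O)c1` is the only one of the three with a number, giving 17800 nM in this assay. Compound 1 therefore stands at the limit of > 50000 nM in this assay, at which 2 of the 3 values shown sit, and nothing further about its strength can be read from that limit.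

Compound 4 `COc1ccc(-c2cc(C)oc(=O)c2)cc1` has not yet been measured in this assay. It differs from compound 1 in a single place: methoxy in place of chloro on an aromatic carbon of a six-membered aromatic ring of carbon only, para to a group of eight heavy atoms. Among the compounds with values here, no step between two measured compounds shows what such an exchange does on this core, so the account rests on compound 1 alone. Since compound 1 sits at a limit, the step of a number no higher from compound 1 to compound 4 (the limit leaves the size open) is expected to be none beyond the scatter, with compound 4 most likely also returning a limit rather than a number. Compound 4 is accordingly estimated at 50000 nM, in the range from 12000 nM to 150000 nM.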

Compound 4, half-maximal inhibitory concentration: > 50000 nM
Compound 4: no number, only a limit (the forecaster's own chance of this, stated with the estimate: 65%); the middle value lies on the limit itself.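

Within the data shown here, compound 4, like compound 1, returns only a limit in this assay, so no step between the two can be read. The compounds shown leave open what methoxy in place of chloro on an aromatic carbon does to inhibition on the shared core, and most of them offer no number for comparison: the limit of > 50000 nM in this assay, at which 3 of the 4 values shown sit.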